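Shortening the chain on the ring nitrogen of compound 2

The compounds below may be only part of what the source reports. "The series", "measured", "known", "first", "only" and "open" are said of these compounds alone.

Of the compounds shown here, three sharing one core have been measured so far in a functional assay (trachea) with Cavia porcellus as the target; on this read-out lower numbers stand for stronger inhibition and higher numbers for weaker inhibition. Compound 1 `CCCn1nc(-c2cccnc2)c2ccccc2c1=O` gives 3160 nM in this assay, compound 2 `CCCCCCCCn1nc(-c2cccnc2)c2ccccc2c1=O` gives 21900 nM, and compound 3 `CC(C)=CCn1nc(-c2cccnc2)c2ccccc2c1=O` gives 1380 nM. Compound 2 thus stands highest of the three: compound 1 is nearest, with a 6.9-fold higher number from compound 1 to compound 2 (0.84 log units; beyond the scatter) on the way to compound 2, and compound 3 furthest, with a 16-fold lower number from compound 2 to compound 3 (1.20 log units; beyond the scatter).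

Compound 4 `CCOC(=O)Cn1nc(-c2cccnc2)c2ccccc2c1=O` differs from compound 2 in one place: ethoxycarbonyl in place of heptyl on a saturated chain carbon bound to an aromatic nitrogen. Among the measured compounds shown here, two measured steps bear on it. The step of a 6.9-fold higher number from compound 1 to compound 2 (0.84 log units; beyond the scatter) shows that lengthening the chain at this position raised the number, and the step of a 16-fold lower number from compound 2 to compound 3 (1.20 log units; beyond the scatter) shows that replacing heptyl with a shorter group lowered it substantially. The change to compound 4 likewise removes heptyl and puts in a shorter group, so a clearly lower number is expected, of the order of a 7.3-fold lower number from compound 2 to compound 4 (0.86 log units; beyond the scatter). Compound 4 is therefore estimated at 3000 nM in this assay, with a range from 1000 nM to 10000 nM.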

Compound 4, half-maximal inhibitory concentration: 43700 nM
Compound 4: the middle estimate sits 15-fold (1.16 log units) below what was measured, outside the stated range (above it).
By their numbers in this assay, from the lowest: compound 3; then compound 1; then compounds 2 and 4 (each within the scatter of the next).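

Compound 4 shows that a shorter group at this place does not by itself lower the number in this assay: exchanging heptyl for ethoxycarbonyl leaves the two compounds within the scatter of each other (a 2.0-fold higher number from compound 2 to compound 4 (0.30 log units; within the scatter)). The gain seen with 2-methylprop-1-en-1-yl therefore does not carry over to every shorter group, and the ethoxycarbonyl compound reads far weaker than both short-chain compounds (a 14-fold higher number from compound 1 to compound 4 (1.14 log units; beyond the scatter); a 32-fold higher number from compound 3 to compound 4 (1.50 log units; beyond the scatter)). Nothing available here accounts for this gap between groups on the same saturated chain carbon bound to an aromatic nitrogen.

The compounds shown leave open whether the ethoxycarbonyl group's oxygen atoms or its particular shape set this result. A carboxylic acid, a primary amide or a plain butyl chain at this place could help separate these possibilities.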